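A few compounds are considered here, and "the series" means these few. Any claim that something is new, unique, unknown or untested is made for them only; others in the source may bear on it.

Of the compounds shown here, three on the shared core have been measured in a functional assay on HeLa cells (Homo sapiens) for antiproliferative activity, read by CCK-8 assay, with a stated time of 72 h, tested at 8 uM; on this read-out higher numbers stand for a stronger effect at the one concentration tested and lower numbers for a weaker effect. Compound 1 `Nc1ccccc1NC(=O)c1ccc(CSC(=S)N2CCN(Cc3ccccn3)CC2)cc1` gives 61.4%. Compound 2 `Nc1ccccc1NC(=O)c1ccc(CSC(=S)N2CCc3cc(Cl)ccc32)cc1` gives 65.1%, a number that sits within the scatter of compound 1. Compound 3 `CC1CCCCN1C(=S)SCc1ccc(C(=O)Nc2ccccc2N)cc1` gives 76.3%, a number above compound 1 beyond the scatter. For the measured compounds named here, the only step between measured neighbours, a number 11.2 percentage points higher from compound 2 to compound 3 (beyond the scatter), concerns the group on the thiocarbonyl carbon and not the part altered here. Compound 4 `Nc1ccccc1NC(=O)c1ccc(CSC(=S)N2CCN(Cc3ccncc3)CC2)cc1` differs from compound 1 by pyridin-4-yl in place of pyridin-2-yl on a saturated chain carbon bound to an amine nitrogen in a ring. Going by the values given here, no measured step bears on this change, so on the data at hand no step beyond the scatter is expected, the estimated step being a number 0.4 percentage points lower from compound 1 to compound 4 (within the scatter). Compound 4 is therefore expected to give about 61%, within the range 50% to 72%.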

Compound 4, a percentage reported as inhibition, at one concentration (the size of the read-out at that concentration, not a potency): 72.9%
Compound 4: middle estimate off by 11.9 percentage points, on the low side; the whole stated range lies below it.
By their numbers in this assay, from the lowest: compounds 1, 2, 4 and 3 (each within the scatter of the next, the first and the last beyond it).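

In this assay, pyridin-4-yl in place of pyridin-2-yl gives a number 11.5 percentage points higher from compound 1 to compound 4 (beyond the scatter), so this position responds to a swap that leaves the atoms and the counted donors and acceptors unchanged. The earlier step concerned only the group on the thiocarbonyl carbon; this one shows that a change further out on the (pyridin-2-yl)methyl group can also move the read-out beyond the scatter. No available evidence accounts for this step. Going by these compounds, whether pyridin-3-yl or a plain phenyl at this place would read like compound 1 or like compound 4 remains open.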